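This account rests on a few compounds, and the source may have more. Where it says the series, first, only, none or still open, it means among the compounds named here.

Compound 2 `COc1ccc2nc(C)cc(OCC(=O)Nc3cccc(C)c3)c2c1` stands lowest of the two numbers measured in a physicochemical assay for lipophilicity, read by HPLC, in phosphate buffer, measured as chromatographic lipophilicity, at pH 7.4; a higher number here means a more lipophilic compound, a lower number a more polar compound: compound 2 gives 4.83, while compound 1 `COc1ccc2nc(C(F)(F)F)cc(OCC(=O)Nc3cc(C)cc(C)c3)c2c1` gives 7.02, a gap beyond the scatter. Going by the values given here, no single-point step between these two has been computed, so nothing more is read from that pair. Compound 3 `COc1ccc2nc(C)cc(OCC(=O)Nc3ccc(Cl)cc3Cl)c2c1` is still to be measured in this assay. It differs from compound 2 in one place: 2,4-dichlorophenyl in place of 3-methylphenyl on an amide-type nitrogen. In this assay a rise beyond the scatter is expected for the step of a number 0.97 log units higher from compound 2 to compound 3 (beyond the scatter). Compound 3 is accordingly estimated at 5.8, within 5.2 to 6.4.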

Compound 3, distribution coefficient: 6.4
Compound 3: middle estimate off by 0.60 log units, on the low side, within the range that was stated.
By their numbers in this assay, from the lowest: compound 2; then compound 3; then compound 1.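

On the amide-type nitrogen, 2,4-dichlorophenyl in place of 3-methylphenyl gives a number 1.57 log units higher from compound 2 to compound 3 (beyond the scatter) in this assay. Going by these compounds alone, this is the first single-place step, and it shows that the group on this nitrogen alone can shift the read-out by a large amount while the rest of compound 2 stays unchanged. Nothing measured here bears on the origin of the step. Still open, going by these compounds, is how a phenyl carrying a single chlorine, an amine or a carboxylic acid would read at this nitrogen. Also open, on these data alone, is whether the step carries over to a core bearing trifluoromethyl, as in compound 1.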